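Hydroxamic acid series: from compound 3 to compound 4

The source may hold more compounds than are shown below. What is called first, only, known or untested is meant among the compounds shown, and "the series" means these compounds.

Measured in a functional assay on ACHN cells (Homo sapiens) for inhibition, read by sulforhodamine B assay; on this read-out lower numbers stand for stronger inhibition of growth and higher numbers for weaker inhibition of growth:
- compound 1 `O=C(CCC1=CCCN(Cc2ccc(F)cc2)C1=O)NO`: "not determined" (no result reported)
- compound 2 `CC(=O)Nc1ccc(CN2CCC=C(CCC(=O)NO)C2=O)cc1`: "not determined" (no result reported)
- compound 3 `Cc1ccccc1CN1CCC=C(CCC(=O)NO)C1=O`: > 10000 nM

Compound 3 gives > 10000 nM, which is a limit of the assay and not a number. Within the data shown here, neither of the other two entries carries a number, so the series has no measured step. Compound 4 `O=C(CCC1=CCCN(Cc2ccc(Br)cc2)C1=O)NO` is next, with this change from compound 3: 4-bromophenyl in place of 2-methylphenyl on a saturated chain carbon bound to an amide-type nitrogen in a ring. The expectation rests on compound 3 alone, whose limit is > 10000 nM. An estimated step of an at least 1.1-fold lower number from compound 3 to compound 4 (0.04 log units; that floor lies within the scatter) is expected in this assay, within the usual scatter and with no favoured direction. For compound 4 the expected value is 9000 nM, with an estimated range of 2500 nM to 30000 nM.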

Compound 4, concentration for 50% growth inhibition: 2480 nM
Beside the measured number, compound 4's estimate is 3.6-fold (0.56 log units) above it; measured number below the stated range.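

In this assay the series gains its first readable step, an at least 4.0-fold lower number from compound 3 to compound 4 (0.60 log units; beyond the scatter), with 4-bromophenyl in place of 2-methylphenyl on a saturated chain carbon bound to an amide-type nitrogen in a ring. The group at this place can therefore move the read-out beyond the scatter. The step is only a floor because compound 3 carries a limit and not a number: the limit of > 10000 nM in this assay, at which 1 of the 4 values shown sits.

Steps involving compound 1 and compound 2 cannot be read. On these data alone, it remains open whether the bromine itself matters, and how 4-chlorophenyl or unsubstituted phenyl would read at this place.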